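Chain length on a shared core: the butyl homologue

The source may hold more compounds than are shown below. What is called first, only, known or untested is meant among the compounds shown, and "the series" means these compounds.

Measured so far:
- Compound 1 `CCCCCc1cc2ccccc2nc1-c1cn(-c2ccc(F)cc2)nn1` — > 100 ug/mL
- Compound 2 `CCc1cc2ccccc2nc1-c1cn(-c2ccc(F)cc2)nn1` — > 100 ug/mL
- Compound 3 `CCCc1cc2ccccc2nc1-c1cn(-c2ccc(F)cc2)nn1` — > 100 ug/mL

In a functional assay on COLO 205 cells (Homo sapiens) for cytotoxicity, read by MTT assay, with a stated time of 24 h (on this read-out lower numbers stand for stronger inhibition and higher numbers for weaker inhibition), compound 1 gives > 100 ug/mL, which is a limit of the assay and not a number. Compound 2 gives > 100 ug/mL, again a limit. Compound 3 gives > 100 ug/mL, also a limit. All three share (the limit of > 100 ug/mL in this assay, at which 3 of the 3 values shown sit), so compound 3 stands exactly where the other two stand, at the edge of what this assay can read.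

The steps among them carry no readable size: a step that the two limits leave unreadable from compound 1 to compound 2, a step that the two limits leave unreadable from compound 1 to compound 3 and a step that the two limits leave unreadable from compound 2 to compound 3 are all hidden by the limits on both sides.

Compound 4 `CCCCc1cc2ccccc2nc1-c1cn(-c2ccc(F)cc2)nn1` differs from compound 3 by methyl in place of hydrogen on a saturated chain carbon, three bonds along the chain from an aromatic carbon. Every step that bears on this change is unreadable, and every measured chain length sits at the limit, so the expected step that the limit leaves unreadable from compound 3 to compound 4 is none beyond the scatter. Compound 4 is therefore estimated at 150 ug/mL, with a range from 80 ug/mL to 500 ug/mL, most likely again reported only as a limit.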

Compound 4, half-maximal inhibitory concentration: > 100 ug/mL
Compound 4 gave a limit, no number; the forecaster's own chance of this, stated with the estimate: 85%; the middle value does not contradict the limit.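

In this assay compound 4 gives > 100 ug/mL, a limit and not a number. No step among compound 1, compound 2, compound 3 and compound 4 can be read: the limit of > 100 ug/mL in this assay, at which 4 of the 4 values shown sit.

The compounds shown leave open whether chain length on the shared core has any effect in this assay.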